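Trimming the aryl ketone of compound 3 to a small thio group

The source may report more compounds than this note shows. Statements on the series, on what has been measured and on what is new or still open speak of the compounds shown alone.

Compounds measured in a functional assay (trachea) with Rattus norvegicus as the target; on this read-out lower numbers stand for lower potency and higher numbers for higher potency (the scale is a negative logarithm):
compound 1 `CC1(C)C=C(n2ccccc2=O)c2cc(C(=O)c3ccc(O)cc3)ccc2O1` 5.87
compound 2 `CC1(C)C=C(n2ccccc2=O)c2cc(C(=O)c3ccccc3F)ccc2O1` 6.34
compound 3 `Cc1ccccc1C(=O)c1ccc2c(c1)C(n1ccccc1=O)=CC(C)(C)O2` 6.25

Compound 3 stands second of the three numbers. Its nearest neighbour is compound 2, and the gap a number 0.09 log units lower from compound 2 to compound 3 (within the scatter) lies within the scatter, so the two cannot be ordered. Its furthest neighbour is compound 1, and the step of a number 0.38 log units higher from compound 1 to compound 3 (beyond the scatter) lies beyond the scatter, as does a number 0.47 log units higher from compound 1 to compound 2 (beyond the scatter).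

Compound 4 `CC1(C)C=C(n2ccccc2=O)c2cc(C(=N)S)ccc2O1` differs from compound 3 in one place: a group of 3 heavy atoms (1 carbon, 1 nitrogen, 1 sulfur; no ring) in place of a group of 9 heavy atoms (8 carbon, 1 oxygen; one six-membered aromatic ring of carbon only), on an aromatic carbon.

The measured steps all concern exchanges of one six-membered aromatic ring of carbon only for another on the carbonyl carbon, and they were modest or within the scatter. None of them removes the (2-methylphenyl)carbonyl altogether, as the step to compound 4 does, so the measured steps bear on it only weakly. The change is far larger than any of the three measured, and the estimate therefore carries wide uncertainty.

Compound 4 is expected to be less potent than compound 3, with a number 1.25 log units lower from compound 3 to compound 4 (beyond the scatter) as the expected step. Compound 4 is estimated at 5, within a range of 4.2 to 5.8.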

Compound 4, logarithm of the reciprocal of the active concentration, log(1/C): 5.96
Compound 4: middle estimate off by 0.96 log units, on the low side; the measured number lies above the stated range.
By their numbers in this assay, from the lowest: compounds 1, 4, 3 and 2 (each within the scatter of the next, the first and the last beyond it).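

The aromatic ring and its carbonyl prove dispensable at this aromatic carbon in this assay: with the whole (2-methylphenyl)carbonyl gone, a number 0.29 log units lower from compound 3 to compound 4 (within the scatter) leaves the two compounds unordered, and a number 0.09 log units higher from compound 1 to compound 4 (within the scatter) does the same against the compound carrying the 4-hydroxyphenyl group. Only the comparison with the 2-fluorophenyl compound reaches beyond the scatter, at a number 0.38 log units lower from compound 2 to compound 4 (beyond the scatter), and that step is modest, so a group of 3 heavy atoms with no ring stays close to the aryl ketones, something the earlier exchanges of one aromatic ring for another could not reveal. Nothing measured here accounts for this tolerance of so large a loss of atoms.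

Still open, going by these compounds, is which part of the entering group carries the result, its sulfur or its nitrogen, and whether the ring-free group's standing depends on either atom. How a primary carboxamide, a nitrile, a carboxylic acid or a longer alkyl chain would read on the same aromatic carbon also remains unanswered by the compounds shown.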